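From an Oxan-4-yl Group to a Hydroxylated Chain

The source may report more compounds than this note shows. Statements on the series, on what has been measured and on what is new or still open speak of the compounds shown alone.

In a functional assay on HUVEC cells (Homo sapiens) for inhibition, using NADPH, with a stated time of 2 h (a lower number here means a stronger inhibitor, a higher number a weaker inhibitor), compound 1 (`Cc1c(COc2cccc(OCC3CCOCC3)c2)[nH]c2ccccc2c1=O`) gives 8.9 nM as its half-maximal inhibitory concentration. Compound 2 (`Cc1c(COc2cc(OCC3CCOCC3)ccn2)[nH]c2ccccc2c1=O`) gives 49 nM and is the weaker inhibitor of the pair, by a gap beyond the scatter. Compound 3 (`Cc1c(COc2cc(OCCC(C)(C)O)ccn2)[nH]c2ccccc2c1=O`) carries 2-hydroxy-2-methylpropyl in place of oxan-4-yl on a saturated chain carbon bound to an oxygen on an aromatic ring. Going by the values given here, no measured pair shows this change. The expected change in this assay is small and upward, with the estimated 1.6-fold higher number from compound 2 to compound 3 (0.21 log units; within the scatter) staying within the scatter. Compound 3 is estimated at 80 nM with 25 nM to 250 nM as the expected range.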

Compound 3, half-maximal inhibitory concentration in the HUVEC assay: 140 nM
Estimate against measurement, compound 3: 1.8-fold (0.24 log units) below, and the stated range covers the measured number.
By their numbers in the HUVEC assay, from the lowest: compound 1; then compound 2; then compound 3.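

The position on a saturated chain carbon bound to an oxygen on an aromatic ring responds to this change: in the HUVEC assay, replacing oxan-4-yl with 2-hydroxy-2-methylpropyl gives a 2.9-fold higher number from compound 2 to compound 3 (0.46 log units; beyond the scatter) and so a weaker inhibitor. In a physicochemical assay for solubility, at pH 6.8 (a higher number here means a more soluble compound, a lower number a less soluble compound), compound 2 gives 36000 nM and compound 3 gives 85000 nM, so the same change brings a gain in solubility alongside that loss: the measured solubility of compound 2, 36000 nM, and of compound 3, 85000 nM, a 2.4-fold higher number (0.37 log units; beyond the scatter)

This single step replaces the ring and adds the hydroxy group together, and it does not separate the two. As far as these compounds go, how an amine, a carboxylic acid or a longer chain would behave at this position remains open.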